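The source may report more compounds than this note shows. Statements on the series, on what has been measured and on what is new or still open speak of the compounds shown alone.

Compound 1 `Oc1ccc(-c2cc(-c3ccc(Cl)cc3)nc(-c3cccs3)c2)cc1`: 4520 nM
Compound 2 `Oc1cccc(-c2cc(-c3ccccc3)nc(-c3ccc(Cl)cc3)c2)c1`: 11600 nM

For the measured compounds named here, in an ADME assay on HEK293 cells (Homo sapiens) for cytotoxicity, read by CCK-8 assay and cell counting, with a stated time of 2 days (a lower number here means a stronger inhibitor, a higher number a weaker inhibitor), compound 2 gives the highest of the two numbers measured so far; compound 1 gives the nearest value, a lower one, and that gap lies beyond the usual scatter. Compound 3 `Oc1ccc(-c2cc(-c3ccccc3)nc(-c3ccc(Cl)cc3)c2)cc1` has not yet been measured; it differs from compound 2 by 4-hydroxyphenyl in place of 3-hydroxyphenyl on an aromatic carbon. Going by the values given here, no step between two measured compounds matches this change on its own. A modest move toward a lower number is expected, perhaps no larger than the scatter, because in this assay compound 1 with 4-hydroxyphenyl gives 4520 nM. Compound 3 is expected to give 6500 nM (range 2500 nM to 16000 nM), a step of a 1.8-fold lower number from compound 2 to compound 3 (0.25 log units; within the scatter).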

Compound 3, half-maximal inhibitory concentration: 4810 nM
Compound 3: the middle estimate sits 1.4-fold (0.13 log units) above what was measured, and the stated range covers the measured number.
By their numbers in this assay, from the lowest: compounds 1 and 3 (each within the scatter of the next); then compound 2.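

In this assay, 4-hydroxyphenyl in place of 3-hydroxyphenyl, opposite the ring nitrogen, gives a 2.4-fold lower number from compound 2 to compound 3 (0.38 log units; beyond the scatter), so where the hydroxyl sits on this ring makes a modest but readable difference. Phenyl in place of thiophen-2-yl gives a 1.1-fold higher number from compound 1 to compound 3 (0.03 log units; within the scatter), so that swap shows no readable effect alongside 4-hydroxyphenyl. No measurement at hand explains the difference between the two hydroxyl placements. As far as these compounds go, whether 4-methoxyphenyl or 4-aminophenyl at this place would give a similar number remains open, as does whether the thiophen-2-yl swap behaves the same alongside 3-hydroxyphenyl.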